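Second Nitro on the Aryl Hydrazone of Compound 1

The source may report more compounds than this note shows. Statements on the series, on what has been measured and on what is new or still open speak of the compounds shown alone.

Measured compounds:
compound 1 `Cc1ccc2[nH]c(=O)c(/C=N/Nc3ccc([N+](=O)[O-])cc3)cc2c1` — 350000 nM
compound 2 `NS(=O)(=O)CC(=O)N/N=C/c1cc2ccccc2[nH]c1=O` — 8730000 nM

Of the compounds shown here, two sharing the quinolinone-derived core have been measured in a functional assay, read by spectrophotometry, with a stated time of 1 h; a higher number here means a weaker inhibitor, a lower number a stronger inhibitor. Compound 1 gives 350000 nM in this assay, the lower of the two numbers. The hydrazone of compound 1 carries a nitrophenyl group, which in compound 2 is replaced by a sulfonamide-bearing acyl group; in this assay compound 2 gives 8730000 nM, a number far beyond the scatter above that of compound 1. Going by the values given here, the two structures differ in more than one place, so this gap says only that compound 1 is the stronger inhibitor of the pair in this assay.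

Compound 3 `Cc1ccc2[nH]c(=O)c(/C=N/Nc3ccc([N+](=O)[O-])cc3[N+](=O)[O-])cc2c1` has not yet been measured. It differs from compound 1 by nitro in place of hydrogen on an aromatic carbon. Among the compounds with values here, no measured pair in this set shows a step of this kind, so there is no direct guide to its size or direction. Given the values of compound 1 and compound 2 alone, the change is expected to move this assay by a small amount, if at all, beyond the scatter. Compound 3 is therefore estimated at 250000 nM, with a range from 80000 nM to 800000 nM, corresponding to an expected step of a 1.4-fold lower number from compound 1 to compound 3 (0.15 log units; within the scatter).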

Compound 3, half-maximal inhibitory concentration: 749000 nM
Estimate against measurement, compound 3: 3.0-fold (0.48 log units) below; the range from low to high includes it.
By their numbers in this assay, from the lowest: compound 1; then compound 3; then compound 2.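

Putting nitro in place of hydrogen on this aromatic carbon, ortho to a large group and meta to a nitro group, gives in this assay a modest loss, a 2.1-fold higher number from compound 1 to compound 3 (0.33 log units; beyond the scatter). Going by these compounds alone, this is the first comparison in the set between compounds that differ in one place, and it shows that a change at this carbon can be read in this assay, with the added nitro moving the number towards weaker inhibition rather than towards stronger. No measurement shown here speaks to why the number moves in this direction.

The compounds shown leave open whether this loss belongs to nitro itself or would follow any group on this carbon; an amine, a methoxy group or a chlorine atom at the same place on the core of compound 1 would tell these readings apart. They also leave open what the nitro already present in compound 1 contributes, which a carboxylic acid or a plain hydrogen in its place would begin to show.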